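The compounds below may be only part of what the source reports. "The series", "measured", "known", "first", "only" and "open" are said of these compounds alone.

Compound 3 `CCCNc1cccc(NC(=O)c2ccc(OCCC)cc2)n1` holds the lowest of the two numbers available in an in vitro assay on HEK-tsA201 cells for antagonist activity at Neuronal acetylcholine receptor; alpha3/beta4 (Homo sapiens), read by fluorescence and calcium flux; a higher number here means a weaker inhibitor, a lower number a stronger inhibitor: compound 3 gives 12600 nM. Compound 1 `C=CCOc1ccc(C(=O)Nc2ccccn2)cc1` is the nearest measured neighbour, and in this assay compound 1 gives 61400 nM. Compound 2 `C=CCOc1ccc(C(=O)Nc2cccc(Cl)n2)cc1` reaches only a limit of this assay, and compound 2 gives > 100000 nM, a limit and not a number (the limit of > 100000 nM in this assay, at which 1 of the 3 values shown sits). Within the data shown here, the single step measured in one place, an at least 1.6-fold higher number from compound 1 to compound 2 (0.21 log units; that floor lies within the scatter), concerns chloro in place of hydrogen on an aromatic carbon.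

Compound 4 `C=CCOc1ccc(C(=O)Nc2cccc(NCCC)n2)cc1` differs from compound 3 in one place: vinyl in place of ethyl on a saturated chain carbon bound to an oxygen on an aromatic ring, that is propyl to allyl, propoxy to allyloxy. Among the measured compounds shown here, no measured step bears on this change. Compound 1 carries the allyloxy chain and compound 3 the propoxy chain, but the two differ in a second place as well, so the gap in which compound 1 gives 61400 nM while compound 3 gives 12600 nM cannot be assigned to the chain alone.

With nothing measured to guide it, the step from compound 3 to compound 4 is expected to be none beyond the scatter, no change at the digits printed from compound 3 to compound 4 (within the scatter). Compound 4 is therefore estimated at 12600 nM in this assay, within a range of 5000 nM to 35000 nM.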

Compound 4, half-maximal inhibitory concentration: 11700 nM
Compound 4: middle estimate off by 1.1-fold (0.03 log units), on the high side, within the range that was stated.
By their numbers in this assay, from the lowest: compounds 4 and 3 (each within the scatter of the next); then compound 1. At a limit, above all of these: compound 2.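

The change of propoxy to allyloxy now has a step of its own, a 1.1-fold lower number from compound 3 to compound 4 (0.03 log units; within the scatter), so with the propylamino group in place the two chains cannot be told apart in this assay. With the allyloxy chain held constant, the aromatic carbon that carried hydrogen or chloro can now be read for propylamino: a 5.2-fold lower number from compound 1 to compound 4 (0.72 log units; beyond the scatter), a step beyond the scatter, whereas the earlier change of hydrogen to chloro gave only a floor within it. The second reading at this carbon, an at least 8.5-fold lower number from compound 2 to compound 4 (0.93 log units; beyond the scatter), is likewise a floor and not a measured gap, as its starting value is a limit: the limit of > 100000 nM in this assay, at which 1 of the 4 values shown sits.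

As far as these compounds go, it remains open whether the allyloxy and propoxy chains also stay level on the core of compound 1, which lacks the propylamino group. From the compounds shown here alone, it is also open whether the step at the aromatic carbon belongs to the propyl chain or to the amine nitrogen alone, a question that an unsubstituted amino group, a longer chain on the nitrogen, or a propoxy group in place of propylamino would address.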